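The compounds below may be only part of what the source reports. "The series", "measured", "known", "first", "only" and "open" are said of these compounds alone.

In a physicochemical assay for solubility, in phosphate buffer, at pH 7.4 (a higher number here means a more soluble compound, a lower number a less soluble compound), compound 1 `c1ccc2nc(N3CC(Oc4nccnc4N4CCCCC4)C3)ccc2c1` gives < 1000 nM, which is a limit and not a number. Going by the values given here, compound 2 `c1ccc(-c2nccnc2OC2CN(c3ccc4ccccc4n3)C2)nc1` stands at 349000 nM, the only true number so far. Among the compounds with values here, the one measured step is an at least 340-fold higher number from compound 1 to compound 2 (2.54 log units; beyond the scatter), made by pyridin-2-yl in place of piperidin-1-yl on an aromatic carbon. Compound 3 `Cc1ncccc1-c1nccnc1OC1CN(c2ccc3ccccc3n2)C1` changes that same carbon: 2-methylpyridin-3-yl in place of pyridin-2-yl on an aromatic carbon, 2-methylpyridin-3-yl in place of pyridin-2-yl. That earlier step, an at least 340-fold higher number from compound 1 to compound 2 (2.54 log units; beyond the scatter), involved a different pair of groups, so it is only a loose guide, and something far smaller is expected here. The expected change is slightly downward, a 1.7-fold lower number from compound 2 to compound 3 (0.24 log units; within the scatter), possibly within the scatter. For compound 3 the estimate is 200000 nM, with an expected range from 50000 nM to 500000 nM.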

Compound 3, solubility: 253000 nM
Compound 3: middle estimate off by 1.3-fold (0.10 log units), on the low side, and the stated range covers the measured number.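

In this assay, 2-methylpyridin-3-yl in place of pyridin-2-yl gives a 1.4-fold lower number from compound 2 to compound 3 (0.14 log units; within the scatter), so the added methyl and the changed point of attachment leave no readable difference at this position. The large step from piperidin-1-yl recurs with a second aromatic group: an at least 250-fold higher number from compound 1 to compound 3 (2.40 log units; beyond the scatter). The value of compound 1 is a limit and not a number: the limit of < 1000 nM in this assay, at which 1 of the 3 values shown sits.

Open, going by these compounds, is where phenyl or morpholin-4-yl would fall on this carbon. The rest of the core is the same in all three compounds, so changes there cannot be judged.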